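A few compounds are considered here, and "the series" means these few. Any claim that something is new, unique, unknown or untested is made for them only; others in the source may bear on it.

Measured so far:
- compound 1 `CCOC(=O)[C@@H]1CCC[C@H](S(=O)(=O)c2ccc(S(=O)(=O)N(CC)CC)cc2)C1`: > 10000 nM in a functional assay on MIA PaCa-2 cells (Homo sapiens) for inhibition, read by MTT assay, with a stated time of 3 days; on this read-out lower numbers stand for stronger inhibition and higher numbers for weaker inhibition; a limit, not a number.
- compound 2 `CCN(CC)S(=O)(=O)c1ccc(S(=O)(=O)N2CCC[C@@H](C(=O)NC3CN(C(=O)C4CC4)C3)C2)cc1`: 3100 nM in this assay.
- compound 3 `CCOC(=O)[C@@H]1CCCN(C(=O)c2ccc(S(=O)(=O)N(CC)CC)cc2)C1`: > 3000 nM in this assay; also a limit.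

Compound 2 thus holds the only number shown in this assay. Compound 1 sits at the limit of > 10000 nM in this assay, at which 1 of the 3 values shown sits. Compound 3 sits at the limit of > 3000 nM in this assay, at which 1 of the 3 values shown sits.

Compound 4 `CCN(CC)S(=O)(=O)c1ccc(S(=O)(=O)N2CCC[C@@H](C(=O)NC3COC3)C2)cc1` differs from compound 2 by oxetan-3-yl in place of 1-(cyclopropylcarbonyl)azetidin-3-yl on an amide-type nitrogen. Within the data shown here, no step between measured compounds covers a change of this kind, so its size in this assay can only be guessed. The step from compound 2 to compound 4 is expected to be a 1.6-fold higher number from compound 2 to compound 4 (0.21 log units; within the scatter), a modest loss or nothing beyond the scatter. For compound 4 the estimate in this assay is 5000 nM, with a span of 2000 nM to 15000 nM.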

Compound 4, half-maximal inhibitory concentration: 900 nM
Beside the measured number, compound 4's estimate is 5.6-fold (0.74 log units) above it; the whole stated range lies above it.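

In this assay, among these compounds, oxetan-3-yl in place of 1-(cyclopropylcarbonyl)azetidin-3-yl on an amide-type nitrogen gives a 3.4-fold lower number from compound 2 to compound 4 (0.54 log units; beyond the scatter) and this is the only step that can be read at this position. The cyclopropylcarbonyl and the azetidine are therefore not required for activity at the level of compound 2, and the smaller group carries the lower number. No measurement shown gives a reason for this step.

Whether the oxetane oxygen or the smaller ring accounts for the step stays open. Also open, from the compounds shown here alone, is how a cyclobutyl, a free azetidin-3-yl amine or a 2-methoxyethyl chain would read on the same nitrogen.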